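Methyl on the amide nitrogen of compound 2

This account rests on a few compounds, and the source may have more. Where it says the series, first, only, none or still open, it means among the compounds named here.

Of the compounds shown here, two built on a shared core have been read so far in an in vitro ADME assay on microsomes from liver (Rattus norvegicus) for metabolic stability; on this read-out higher numbers stand for fast clearance and lower numbers for slow clearance. There, compound 1 `CC[C@H](C)[C@@H]1C(=O)N[C@H](C2Cc3ccccc3C2)C(=O)N1[C@@H](C(=O)N(C)C)c1cnc(C)cc1C` gives 1 mL.min-1.g-1, and compound 2 `CC[C@H](C)[C@@H]1C(=O)N[C@H](C2Cc3ccccc3C2)C(=O)N1[C@@H](C(=O)NC)c1cc(C)cnc1C` gives 1 mL.min-1.g-1, so the two stand level. Compound 3 `CC[C@H](C)[C@@H]1C(=O)N[C@H](C2Cc3ccccc3C2)C(=O)N1[C@@H](C(=O)N(C)C)c1cc(C)cnc1C` is still to be measured in this assay.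

Going from compound 2 to compound 3, the change is methyl in place of hydrogen on an amide-type nitrogen, which turns methylcarbamoyl into dimethylcarbamoyl. Among the measured compounds shown here, no measured pair isolates this change, so there is no direct precedent for its size. The nearest guide is compound 1, which already carries a dimethylcarbamoyl group and reads 1 mL.min-1.g-1. The expected step of a 1.3-fold higher number from compound 2 to compound 3 (0.11 log units; within the scatter) stays within the usual scatter, with only a slight lean towards faster clearance. The range is kept wider on the upper side, since two level values offer little evidence. For compound 3 the estimated value is 1.3 mL.min-1.g-1. The expected range for compound 3 runs from 0.6 mL.min-1.g-1 to 3.5 mL.min-1.g-1.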

Compound 3, intrinsic clearance in microsomes: 1 mL.min-1.g-1
Compound 3: the middle estimate sits 1.3-fold (0.11 log units) above what was measured; the measured number falls inside the stated range.
By their numbers in this assay, from the lowest: compounds 1, 2 and 3 (each within the scatter of the next).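

In this assay the change of methyl in place of hydrogen on the amide-type nitrogen, which turns methylcarbamoyl into dimethylcarbamoyl, now has a direct reading of no change at the digits printed from compound 2 to compound 3 (within the scatter) on this core, so this nitrogen tolerates the added methyl with no visible cost or gain in this read-out. With the dimethylcarbamoyl group held in place, 2,5-dimethylpyridin-3-yl in place of 4,6-dimethylpyridin-3-yl gives no change at the digits printed from compound 1 to compound 3 (within the scatter), so the arrangement of the two methyl groups on the pyridine also leaves the reading level, and neither change could be read alone from the earlier pair. No supporting data bear on the reason for either reading.

The compounds shown leave open whether a longer chain on this nitrogen, such as ethyl or 2-methoxyethyl, or the primary amide carrying two hydrogens, would stay level in this assay. Also open, from the compounds shown here alone, is whether the pyridine tolerates replacing one of its methyl groups with chloro or methoxy while the reading stays level.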